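This account rests on a few compounds, and the source may have more. Where it says the series, first, only, none or still open, it means among the compounds named here.

Of the compounds shown here, two have been tested in a functional assay on Z-138 cells (Homo sapiens) for inhibition, read by luminescence and CellTiter-Glo, with a stated time of 72 h; on this read-out higher numbers stand for weaker inhibition and lower numbers for stronger inhibition. Compound 2 `O=C(CCl)Nc1ccc(Cn2nc(-c3ccc(Oc4ccccc4)cc3)cc2C(=O)O)cc1` gives 1500 nM in this assay, the lowest of the two numbers recorded. Its nearest neighbour is compound 1 `C=CC(=O)Nc1cccc(Cn2nc(-c3ccc(Oc4ccccc4)cc3)cc2CO)c1`, which in this assay gives 6000 nM, a gap beyond the usual scatter of repeated measurements. Within the data shown here, no pair of compounds measured so far differs in just one place, so no single step has been measured yet.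

Compound 3 `C=CC(=O)Nc1cccc(Cn2nc(-c3ccc(Oc4ccccc4)cc3)cc2C(=O)O)c1` has not yet been measured in this assay. It differs from compound 2 in one place: 3-((vinylcarbonyl)amino)phenyl in place of 4-(((chloromethyl)carbonyl)amino)phenyl on a saturated chain carbon bound to an aromatic nitrogen. The group that enters is the same one found in compound 1, although compound 1 also differs from compound 3 in a second place, so the comparison with compound 1 is only a loose guide.

Given that compound 1, carrying the entering group, gives 6000 nM, a modest rise in number from compound 2 to compound 3 is expected, estimated as a 2.0-fold higher number from compound 2 to compound 3 (0.30 log units; within the scatter), a step of a size that may or may not reach beyond the scatter. Compound 3 is therefore expected to give about 3000 nM in this assay, most likely within 1000 nM to 9000 nM.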

Compound 3, half-maximal inhibitory concentration: 28500 nM
Compound 3: the middle estimate sits 9.5-fold (0.98 log units) below what was measured; measured number above the stated range.
By their numbers in this assay, from the lowest: compound 2; then compound 1; then compound 3.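

In this assay, replacing 4-(((chloromethyl)carbonyl)amino)phenyl with 3-((vinylcarbonyl)amino)phenyl on a saturated chain carbon bound to an aromatic nitrogen brings a 19-fold higher number from compound 2 to compound 3 (1.28 log units; beyond the scatter), so inhibition here depends strongly on which of these two groups is present, even though they hold equal numbers of heavy atoms. Among these compounds, the carboxy group is no guarantee of a low number either: with 3-((vinylcarbonyl)amino)phenyl held constant, carboxy in place of hydroxymethyl on an aromatic carbon gives a 4.8-fold higher number from compound 1 to compound 3 (0.68 log units; beyond the scatter), the first measured single change at that second place. No measurement at hand explains why either step goes the way it does.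

The step from compound 2 to compound 3 alters both the reactive-looking end of the amide, chloromethyl against vinyl, and the number in the group's name, 4 against 3, so the compounds shown cannot say which of these matters; 4-((vinylcarbonyl)amino)phenyl or 3-(((chloromethyl)carbonyl)amino)phenyl on the same core would separate the two. On these data alone, it also remains open how a methyl ester or a primary amide would behave in place of the carboxy group.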